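This account rests on a few compounds, and the source may have more. Where it says the series, first, only, none or still open, it means among the compounds named here.

Measured compounds:
Compound 1 `C=C[C@@](C)(/C=C/c1ccc(O)c(/C=C/c2ccc(Cl)cc2)c1)CCC=C(C)C`: in a functional assay on HepG2 cells (Homo sapiens) for cytotoxicity, with a stated time of 72 h (on this read-out higher numbers stand for an effect only at larger amounts of compound and lower numbers for an effect already at smaller amounts), compound 1 gives > 52000 nM, a limit of the assay.
Compound 2 `C=C[C@@](C)(/C=C/c1ccc(O)c(/C=C/c2ccc(Cl)c(Cl)c2)c1)CCC=C(C)C`: in this assay compound 2 gives > 52000 nM, also a limit.
Compound 3 `C=C[C@@](C)(/C=C/c1ccc(Nc2ccc(Cl)cc2)cc1)CCC=C(C)C`: in this assay compound 3 gives > 52000 nM, again a limit.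

The change from compound 1 to compound 2 is chloro in place of hydrogen on an aromatic carbon. The step it made, a step that the two limits leave unreadable from compound 1 to compound 2, cannot be sized, as both values are limits. Compound 4 `C=C[C@@](C)(/C=C/c1ccc(Nc2ccc(Cl)c(Cl)c2)cc1)CCC=C(C)C` carries the same change on the core of compound 3: chloro in place of hydrogen on an aromatic carbon, at the same place in the same words. How the cores of compound 3 and compound 1 differ is not broken down here. All three measured values sit together at the limit of > 52000 nM in this assay, at which 3 of the 3 values shown sit. The step from compound 3 to compound 4 in this assay is expected to be a step that the limit leaves unreadable from compound 3 to compound 4, an expectation that rests on (the limit of > 52000 nM in this assay, at which 3 of the 3 values shown sit), where the earlier pair and compound 3 all stand. Compound 4 is estimated at 80000 nM, expected between 30000 nM and 250000 nM, most likely reported only as a limit.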

Compound 4, half-maximal effective concentration: > 52000 nM
Compound 4: no number, only a limit; the forecaster's own chance of this, stated with the estimate: 90%; the middle value is on the limit's open side.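

The step between compound 3 and compound 4 cannot be read, as both values are limits: the limit of > 52000 nM in this assay, at which 4 of the 4 values shown sit.

The compounds shown leave open whether chloro in place of hydrogen on an aromatic carbon changes anything in this assay, and at what concentration any effect would appear.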